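This account rests on a few compounds, and the source may have more. Where it says the series, first, only, none or still open, it means among the compounds named here.

Measured compounds and their values:
compound 1, `Cc1cc(Br)c(S(C)(=O)=O)cc1C(=O)N=C(N)N`: 12 nM
compound 2, `CCC(C)c1cc(C)c(C(=O)N=C(N)N)cc1S(C)(=O)=O`: 8 nM
compound 3, `Cc1cc(Sc2ccccc2Cl)c(S(C)(=O)=O)cc1C(=O)N=C(N)N`: 14 nM

All three share one core and differ only in the group on one aromatic carbon; each was tested in a functional assay for inhibition of sodium/hydrogen exchanger (Oryctolagus cuniculus); on this read-out higher numbers stand for weaker inhibition and lower numbers for stronger inhibition. Compound 3 gives the largest of the three numbers, yet its separation from the others is slight: a 1.2-fold higher number from compound 1 to compound 3 (0.07 log units; within the scatter) and a 1.8-fold higher number from compound 2 to compound 3 (0.24 log units; within the scatter) both lie within the scatter, as does a 1.5-fold lower number from compound 1 to compound 2 (0.18 log units; within the scatter). Three quite different groups at the same aromatic carbon thus give numbers that cannot be told apart in this assay.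

Compound 4, `Cc1cc(O)c(S(C)(=O)=O)cc1C(=O)N=C(N)N`, has not yet been measured. It differs from compound 3 by hydroxy in place of (2-chlorophenyl)sulfanyl on an aromatic carbon. For the measured compounds named here, no measured step places a hydroxy, or any hydrogen-bond donor, at this carbon. Going by the values given here, the steps that bear on the change are the three above, all within the scatter, which show the position taking bromo, sec-butyl and (2-chlorophenyl)sulfanyl alike. On that basis no step beyond the scatter is expected in this assay, though the hydrogen-bond donor is new here, so the range is kept wide. Compound 4 is estimated at 25 nM, between 6 nM and 120 nM, which means an expected step of a 1.8-fold higher number from compound 3 to compound 4 (0.25 log units; within the scatter).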

Compound 4, half-maximal inhibitory concentration: 220 nM
Estimate against measurement, compound 4: 8.8-fold (0.94 log units) below, and the stated range ends below it.
By their numbers in this assay, from the lowest: compounds 2, 1 and 3 (each within the scatter of the next); then compound 4.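

In this assay this aromatic carbon proved not to be indifferent to what it carries: hydroxy in place of bromo gives a large rise (an 18-fold higher number from compound 1 to compound 4 (1.26 log units; beyond the scatter)), as does hydroxy in place of sec-butyl (a 28-fold higher number from compound 2 to compound 4 (1.44 log units; beyond the scatter)) and hydroxy in place of (2-chlorophenyl)sulfanyl (a 16-fold higher number from compound 3 to compound 4 (1.20 log units; beyond the scatter)). All three steps lie beyond the scatter and point the same way, so compound 4 stands apart from compound 1, compound 2 and compound 3, whose numbers cannot be told apart, and the position's earlier acceptance of very different groups did not extend to hydroxy. For the compounds shown here, nothing given here explains the change, and hydroxy is the only group in this set with a hydrogen-bond donor, so this single compound cannot tie the loss to that donor rather than to anything else that differs.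

The compounds shown leave open whether the higher number belongs to hydroxy alone or also comes with methoxy, an amine or plain hydrogen at this carbon. They also leave open whether a carboxylic acid or a longer alkyl chain here would behave like hydroxy or like bromo and sec-butyl.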